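The source may hold more compounds than are shown below. What is called first, only, known or untested is meant among the compounds shown, and "the series" means these compounds.

Series, measured in a functional assay on HCT-116 cells (Homo sapiens) for inhibition, read by MTT assay, with a stated time of 24 h, tested at 10 uM; a lower number here means less inhibition of growth, a higher number more inhibition of growth at the concentration tested:
compound 1 `CS(=O)(=O)c1ccc(-c2cnc3[nH]cc(-c4nnc(-c5ccncc5)o4)c(=O)c3c2)cc1` gives 7.83%
compound 2 `CS(=O)(=O)c1ccc(-c2cnc3[nH]cc(-c4nnc(-c5ccc(F)cc5)o4)c(=O)c3c2)cc1` gives 18.7%
compound 3 `O=c1c(-c2nnc(-c3ccc(F)cc3)o2)c[nH]c2ncc(-c3cccnc3)cc12` gives 19.7%

Compound 2 stands second highest of the three; compound 3 sits within the scatter of it, and compound 1 lies beyond the scatter below it, as the step of a number 10.9 percentage points higher from compound 1 to compound 2 (beyond the scatter) shows. The step of a number 1 percentage points higher from compound 2 to compound 3 (within the scatter) is within the scatter.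

Compound 4 `CS(=O)(=O)c1ccc(-c2cnc3[nH]cc(-c4nnc(-c5ccccn5)o4)c(=O)c3c2)cc1` differs from compound 2 in one place: pyridin-2-yl in place of 4-fluorophenyl on an aromatic carbon.

Among the compounds with values here, the one step that bears on this is the step from compound 1 to compound 2, where 4-fluorophenyl replaced pyridin-4-yl and gave a number 10.9 percentage points higher from compound 1 to compound 2 (beyond the scatter). Compound 4 reverses that direction of change, with pyridin-2-yl entering, so a modest fall in this assay is expected, of about a number 8.7 percentage points lower from compound 2 to compound 4 (within the scatter).

Compound 4 is therefore estimated at 10%, expected range 2% to 20%.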

Compound 4, percent growth inhibition at one concentration: 16.2%
The estimate for compound 4 lay 6.2 percentage points below the measured number, and the stated range covers the measured number.
By their numbers in this assay, from the lowest: compounds 1, 4, 2 and 3 (each within the scatter of the next, the first and the last beyond it).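

Pyridin-2-yl on this aromatic carbon of the five-membered ring is not separated from 4-fluorophenyl in this assay with a number 2.5 percentage points lower from compound 2 to compound 4 (within the scatter) and is not separated from pyridin-4-yl either, with a number 8.4 percentage points higher from compound 1 to compound 4 (within the scatter) in the same read-out. Compound 4 thus sits within the scatter of both neighbours, so swapping these rings does not resolve the gap between compound 1 and compound 2. Nothing measured here offers an explanation for these steps.

From the compounds shown here alone, whether an amine, a carboxylic acid or a morpholine ring at this carbon would shift the number remains open.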